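The source may hold more compounds than are shown below. What is called first, only, known or untested is meant among the compounds shown, and "the series" means these compounds.

Measured compounds:
Compound 1, `CCOc1cc(NC(=O)C2(NC(=O)c3ccc4c(C5CCCC5)c(-c5ncc(Cl)cn5)n(C)c4c3)CCC2)ccc1/C=C/C(=O)OCc1ccccc1`: in an ADME assay (liver) for pharmacokinetics, with Liver microsome (Rattus norvegicus) as the target, using microsomes (a lower number here means that the compound disappears faster, a higher number that the compound lasts longer), compound 1 gives 2.17 h.
Compound 2, `CCOc1cc(NC(=O)C2(NC(=O)c3ccc4c(C5CCCC5)c(-c5ncc(Cl)cn5)n(C)c4c3)CCC2)ccc1/C=C/C(=O)OCCOc1ccccc1`: in this assay compound 2 gives 16.5 h.

Compound 2 stands highest of the two numbers in this assay. Among the compounds with values here, the only measured step is a 7.6-fold higher number from compound 1 to compound 2 (0.88 log units; beyond the scatter), a change of the ester tail at the same place as the one now considered. Compound 3, `CCOc1cc(NC(=O)C2(NC(=O)c3ccc4c(C5CCCC5)c(-c5ncc(Cl)cn5)n(C)c4c3)CCC2)ccc1/C=C/C(=O)OCC(=O)OCc1ccc(Cl)cc1`, differs from compound 2 by ((4-chlorobenzyl)oxy)carbonyl in place of phenoxymethyl on a saturated chain carbon bound to an oxygen next to a carbonyl group. That one step shows the ester tail can shift the half-life well beyond the scatter, but gives no direction for this new tail. A step of a 3.3-fold lower number from compound 2 to compound 3 (0.52 log units; beyond the scatter) is expected, downward and with wide spread. Compound 3 is estimated at 5 h, between 1.5 h and 16 h.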

Compound 3, half-life: 11.4 h
The estimate for compound 3 lay 2.3-fold (0.36 log units) below the measured number, and the stated range covers the measured number.
By their numbers in this assay, from the lowest: compound 1; then compounds 3 and 2 (each within the scatter of the next).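

In this assay there is a 1.4-fold lower number from compound 2 to compound 3 (0.16 log units; within the scatter), so at this place on a saturated chain carbon bound to an oxygen next to a carbonyl group, ((4-chlorobenzyl)oxy)carbonyl and phenoxymethyl are not separated. Against the phenyl tail there is a 5.3-fold higher number from compound 1 to compound 3 (0.72 log units; beyond the scatter), so two different tails now stand beyond the scatter from phenyl. No measurement here accounts for these differences. Open, going by these compounds, is whether the aromatic ring in the tail is needed at all, which a plain ethyl chain, an amine or a carboxylic acid at this place would test. Also open, on these data alone, is what the chlorine contributes to ((4-chlorobenzyl)oxy)carbonyl.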